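Methylsulfanyl for methylsulfonyl: working notes on the series

The compounds below may be only part of what the source reports. "The series", "measured", "known", "first", "only" and "open" are said of these compounds alone.

Measured so far in a functional assay on DU-145 cells (Homo sapiens) for inhibition, read by MTT assay, with a stated time of 48 h; on this read-out higher numbers stand for weaker inhibition and lower numbers for stronger inhibition

- compound 1 `CS(=O)(=O)c1ccc(-c2nc3ccccn3c2Sc2ccccc2)cc1` gives 67800 nM
- compound 2 `COc1ccc(-c2nc3ccccn3c2Sc2ccccc2)cc1` gives 76800 nM
- compound 3 `C(=C/c1nc2ccccn2c1Sc1ccccc1)\c1ccccc1` gives 22000 nM

Compound 1 sits at the upper end of these numbers together with compound 2, and the two are level within the scatter. Compound 3 gives a lower number than compound 1.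

Compound 4 `CSc1ccc(-c2nc3ccccn3c2Sc2ccccc2)cc1` is still unmeasured. It differs from compound 1 at one place (methylsulfanyl in place of methylsulfonyl on an aromatic carbon): methylsulfanyl in place of methylsulfonyl on an aromatic carbon, para to a large group.

The closest evidence comes from compound 2, where methoxy replaces the same methylsulfonyl and the result stays within the scatter (a 1.1-fold higher number from compound 1 to compound 2 (0.05 log units; within the scatter)). The step to compound 3 is modest but beyond the scatter (a 3.5-fold lower number from compound 2 to compound 3 (0.54 log units; beyond the scatter)). That step swaps the whole 4-methoxyphenyl for 2-phenylethenyl, so it says little about the present change. Only one replacement of methylsulfonyl has been measured, which leaves the expectation thinly supported.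

The expected step is small (a 1.0-fold lower number from compound 1 to compound 4 (0.02 log units; within the scatter)), and no shift beyond the scatter is anticipated in this assay in either direction. Compound 4 is estimated at 65000 nM (expected range 30000 nM to 130000 nM).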

Compound 4, half-maximal inhibitory concentration: 52100 nM
Estimate against measurement, compound 4: 1.2-fold (0.10 log units) above, within the range that was stated.
By their numbers in this assay, from the lowest: compound 3; then compounds 4, 1 and 2 (each within the scatter of the next).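

In this assay, methylsulfanyl in place of methylsulfonyl on the aromatic carbon, para to a large group, stays within the scatter (a 1.3-fold lower number from compound 1 to compound 4 (0.11 log units; within the scatter)), and so does methylsulfanyl in place of methoxy (a 1.5-fold lower number from compound 2 to compound 4 (0.17 log units; within the scatter)), so compounds 1, 2 and 4 now form a set of three level numbers at this position, and going from 4 heavy atoms to 2, from 2 hydrogen-bond acceptors to 1, and to no double bonds outside aromatic rings leaves the number within the scatter. Compound 3 remains apart from this set, since the replacement of the whole aryl group is beyond the scatter (a 2.4-fold higher number from compound 3 to compound 4 (0.37 log units; beyond the scatter)), which places the only clear difference in the series at that larger change and not at the group on the aromatic carbon. No supporting measurement bears on why these three groups read alike.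

On these data alone, whether an amine, a carboxylic acid or a longer chain such as butoxy at this aromatic carbon would also stay level with compounds 1, 2 and 4 remains open. Also open, as far as these compounds go, is whether the group on the aromatic carbon matters in any other assay or on any other cell line.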